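The compounds below may be only part of what the source reports. "The series", "measured", "known", "first", "only" and "open" are said of these compounds alone.

Values in a functional assay on the whole organism with Rattus norvegicus as the target; on this read-out lower numbers stand for an effect already at smaller amounts and higher numbers for an effect only at larger amounts of compound:
- Compound 1 `CCOC(=O)C(=O)Nc1cccc(N)c1C#N` gives 0.05 mg/kg
- Compound 2 `CCNc1cccc(NC(=O)C(=O)OCC)c1C#N` gives 0.03 mg/kg

Within the data shown here, compound 2 lies within the scatter of compound 1 , the only other compound measured so far, so the two cannot be told apart. Compound 3 `CCOC(=O)C(=O)Nc1cccc(N(CC)CC)c1C#N` has ethyl in place of hydrogen on a nitrogen on an aromatic ring and so turns ethylamino into diethylamino. Among the measured compounds shown here, one measured step bears on this change, the same replacement on the same nitrogen: a 1.7-fold lower number from compound 1 to compound 2 (0.22 log units; within the scatter) and nothing else is available as a guide. A single pair is thin evidence, and a second ethyl need not behave like the first, so the range is kept wide. No step beyond the scatter is expected in this assay, and the estimated step is a 1.3-fold higher number from compound 2 to compound 3 (0.12 log units; within the scatter) at most a small one. Compound 3 is estimated at 0.04 mg/kg, with 0.01 mg/kg to 0.15 mg/kg as the expected range.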

Compound 3, dose for half-maximal effect: 0.7 mg/kg
Compound 3: middle estimate off by 18-fold (1.24 log units), on the low side; the measured number lies above the stated range.
By their numbers in this assay, from the lowest: compounds 2 and 1 (each within the scatter of the next); then compound 3.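

On this aromatic nitrogen, the two ethyl groups do not count the same: the step from amino to ethylamino stays within the scatter, while adding the second ethyl gives a 23-fold higher number from compound 2 to compound 3 (1.37 log units; beyond the scatter) in this assay. Set against the plain amino group, diethylamino gives a 14-fold higher number from compound 1 to compound 3 (1.15 log units; beyond the scatter), so the change that compound 2 tolerates on this nitrogen cannot simply be repeated, and the effect of an added ethyl depends on what the nitrogen already carries. No measurement at hand accounts for this sharp rise.

On these data alone, it remains open whether the loss comes with any second group on this nitrogen or only with more carbon there. Dimethylamino, or a single longer chain such as butylamino, would separate these two readings.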